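The source may hold more compounds than are shown below. What is called first, only, known or untested is meant among the compounds shown, and "the series" means these compounds.

Measured in a functional assay on DU-145 cells (Homo sapiens) for inhibition, read by trypan blue exclusion, with a stated time of 96 h; on this read-out higher numbers stand for weaker inhibition of growth and lower numbers for stronger inhibition of growth:
- compound 1 `CSc1ccc(/C=C(/Sc2ccc(C)cc2)C(=O)c2ccc(Br)cc2)cc1`: 50000 nM
- compound 2 `CSc1ccc(/C=C(/SCc2ccc(C)cc2)C(=O)c2ccc(Br)cc2)cc1`: > 100000 nM (a limit of the assay, not a number)
- compound 3 `Cc1ccc(S/C(=C/c2ccc(Oc3ccccc3)cc2)C(=O)c2ccc(Br)cc2)cc1`: 1000 nM

Of the two actual numbers, compound 1 holds the higher one. Compound 4 `Cc1ccc(S/C(=C/c2c(O)cc(O)cc2O)C(=O)c2ccc(Br)cc2)cc1` differs from compound 1 by 2,4,6-trihydroxyphenyl in place of 4-(methylsulfanyl)phenyl on a double-bonded chain carbon bound to a double-bonded chain carbon. The step made at this same place is a 50-fold lower number from compound 1 to compound 3 (1.70 log units; beyond the scatter), which is large. The step on the sulfur, an at least 2.0-fold higher number from compound 1 to compound 2 (0.30 log units; that floor lies within the scatter), lies elsewhere and does not bear on this change. For the measured compounds named here, only that one phenoxy step informs the change, so a lower number in this assay is expected, though a smaller drop than in compound 3 at 1000 nM. The expected change is a 6.3-fold lower number from compound 1 to compound 4 (0.80 log units; beyond the scatter). Compound 4 is estimated at 8000 nM, within 800 nM to 60000 nM.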

Compound 4, concentration for 50% growth inhibition: > 100000 nM
Compound 4 gave a limit, no number; the forecaster's own chance of this, stated with the estimate: 15%; middle value at least 12-fold (1.09 log units) away from the limit.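

In this assay, the step is an at least 2.0-fold higher number from compound 1 to compound 4 (0.30 log units; that floor lies within the scatter), so the drop of a 50-fold lower number from compound 1 to compound 3 (1.70 log units; beyond the scatter) does not carry over to 2,4,6-trihydroxyphenyl at this place. Compound 4 gives > 100000 nM, a limit of the assay and not a number. How far compound 4 lies from compound 1 cannot be read, because its value stops at the end of the measured range: the limit of > 100000 nM in this assay, at which 2 of the 4 values shown sit.

Which of the hydroxyl groups matter remains open. Also open, on these data alone, is how an amine or a carboxylic acid on this aromatic ring would read out.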